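A Methyl Added Beyond the Amide Nitrogen

The source may hold more compounds than are shown below. What is called first, only, known or untested is meant among the compounds shown, and "the series" means these compounds.

Compound 1 `O=C(Nc1ccc(O)cc1)c1c(NO)cc(-c2ccccc2)oc1=O` in an ADME assay on Huh-7 cells (Homo sapiens) for cytotoxicity, read by a luciferase reporter and WST assay, with a stated time of 3 days (a lower number here means that less compound is tolerated, a higher number that more compound is tolerated), gives > 20000 nM, a limit.
Compound 2 `COc1ccc(NC(=O)c2c(NO)cc(-c3ccccc3)oc2=O)cc1` gives > 20000 nM, a limit.
Compound 3 `CCNC(=O)c1c(NO)cc(-c2ccccc2)oc1=O` gives > 20000 nM, a limit.

Compound 3 thus stands only at a limit of this assay, and the two other values are limits as well. The steps a step that the two limits leave unreadable from compound 1 to compound 2, a step that the two limits leave unreadable from compound 1 to compound 3 and a step that the two limits leave unreadable from compound 2 to compound 3 cannot be read in size because of the limit of > 20000 nM in this assay, at which 3 of the 3 values shown sit. Compound 4 `CCCNC(=O)c1c(NO)cc(-c2ccccc2)oc1=O` differs from compound 3 by methyl in place of hydrogen on a saturated chain carbon, two bonds along the chain from an amide-type nitrogen. Among the compounds with values here, no measured step bears on this change with a readable size, so no step beyond the scatter is expected for a step that the limit leaves unreadable from compound 3 to compound 4. Compound 4 is therefore estimated at 30000 nM, within 15000 nM to 80000 nM, and most likely again reported only as a limit.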

Compound 4, half-maximal cytotoxic concentration: > 20000 nM
Compound 4: no number, only a limit (the forecaster's own chance of this, stated with the estimate: 85%); the middle value is on the limit's open side.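

The steps to compound 4 from compound 1, compound 2 and compound 3 cannot be read in size, because all rest on one limit: the limit of > 20000 nM in this assay, at which 4 of the 4 values shown sit.
The compounds shown leave open whether ethyl, propyl, 4-hydroxyphenyl and 4-methoxyphenyl on the amide-type nitrogen differ at all in cytotoxicity.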